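One Fewer Methyl: Expected Partition of Compound 4

This account rests on a few compounds, and the source may have more. Where it says the series, first, only, none or still open, it means among the compounds named here.

Compound 1 `CC(O)COc1ccccc1Cl`: 2.05 in a physicochemical assay for lipophilicity, measured as octanol-water partition; a lower number here means a more polar compound, a higher number a more lipophilic compound
Compound 2 `Cc1cccc(Cl)c1OCC(C)O`: 2.73
Compound 3 `Cc1cc(OCC(C)O)cc(C)c1Cl`: 3.18

Compound 3 gives the highest of the three numbers in this assay. The measured step of a number 0.68 log units lower from compound 2 to compound 1 (beyond the scatter) belongs to the change (hydrogen in place of methyl on an aromatic carbon). Compound 4 `Cc1cc(OCC(C)O)ccc1Cl` has not yet been measured; it is made from compound 3 by hydrogen in place of methyl on an aromatic carbon. This is the same kind of change as before, though the surroundings differ: here the carbon is ortho to a chloro group and meta to a methyl group and to the group of 5 heavy atoms, whereas earlier it was ortho to the group of 5 heavy atoms and meta to a chloro group. How the cores of compound 2 and compound 3 differ is not broken down here. Because a number 0.68 log units lower from compound 2 to compound 1 (beyond the scatter) was modest, a step of similar size a number 0.60 log units lower from compound 3 to compound 4 (beyond the scatter) is expected for compound 4. Compound 4 is therefore estimated at 2.58, expected between 2.3 and 2.9.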

Compound 4, partition coefficient: 2.67
Estimate against measurement, compound 4: 0.09 log units below; the measured number falls inside the stated range.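

In this assay, hydrogen in place of methyl on an aromatic carbon gave a number 0.51 log units lower from compound 3 to compound 4 (beyond the scatter) and so ran the same way as a number 0.68 log units lower from compound 2 to compound 1 (beyond the scatter) on the other core, with both steps modest, even though the carbon stands ortho to a chloro group only in the newer pair. Two pairs show that the change carried over between these two cores, but they do not show that it would do so on every core or at every position. Nothing measured here explains the size of either step.

Going by these compounds, whether the step holds in compounds carrying an amine or a carboxylic acid remains open. So does its behaviour with a longer chain in place of the group of 5 heavy atoms.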